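Cytotoxicity in Raji Cells: Three Limits and a Fourth Compound

A few compounds are considered here, and "the series" means these few. Any claim that something is new, unique, unknown or untested is made for them only; others in the source may bear on it.

Compound 1 `COc1cc(OC)cc(-c2ccc(C(=O)N(Cc3cccc(OCCCCCC(=O)O)c3)C(C)C)cc2)c1` gives only a limit of the assay in an ADME assay on Raji cells (Homo sapiens) for cytotoxicity, read by CellTiter-Glo and resazurin assay, with a stated time of 72 h; on this read-out lower numbers stand for an effect already at smaller amounts and higher numbers for an effect only at larger amounts of compound: > 26000 nM.
Compound 2 `CC(C)N(Cc1cccc(OCCCCCC(=O)O)c1)C(=O)c1ccc(-c2cccc(O)c2)cc1` gives only a limit: > 26000 nM.
Compound 3 `CCOC(=O)CCCCCOc1cccc(CN(C(=O)c2ccc(-c3cc(OC)cc(OC)c3)cc2)C(C)C)c1` gives only a limit: > 26000 nM.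

Among the measured compounds shown here, all three measured values sit at the same limit (the limit of > 26000 nM in this assay, at which 3 of the 3 values shown sit), so no step between them can be read as a number. From compound 1 to compound 2 the change is 3-hydroxyphenyl in place of 3,5-dimethoxyphenyl on an aromatic carbon, and the step is a step that the two limits leave unreadable from compound 1 to compound 2. The cores of compound 1 and compound 3 differ by ethyl in place of hydrogen on an oxygen next to a carbonyl group, and that step is a step that the two limits leave unreadable from compound 1 to compound 3.

Compound 4 `CCOC(=O)CCCCCOc1cccc(CN(C(=O)c2ccc(-c3cccc(O)c3)cc2)C(C)C)c1` is not yet measured. It differs from compound 3 by 3-hydroxyphenyl in place of 3,5-dimethoxyphenyl on an aromatic carbon, the same change, at the same place, that was made from compound 1 to compound 2. In this assay the step is expected to be a step that the limit leaves unreadable from compound 3 to compound 4, set beside the earlier one; this expectation rests on the fact that the once‑measured version of this change, a step that the two limits leave unreadable from compound 1 to compound 2, left both of its partners at the limit. Compound 4 is therefore estimated at 40000 nM, within 20000 nM to 100000 nM, most probably reported again only as a limit.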

Compound 4, half-maximal effective concentration: > 26000 nM
Compound 4: only a limit was reported; the forecaster's own chance of this, stated with the estimate: 80%; the middle value is on the limit's open side.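

In this assay compound 4 also gives only a limit, so its steps from compound 3 and from compound 2 cannot be read as sizes, because all the compounds sit at the same limit: the limit of > 26000 nM in this assay, at which 4 of the 4 values shown sit.
The compounds shown leave open at what amount any of them would show an effect, and whether either change makes any difference.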